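A few compounds are considered here, and "the series" means these few. Any claim that something is new, unique, unknown or untested is made for them only; others in the source may bear on it.

Measured so far in an ADME assay on CHO-K1 cells (Cricetulus griseus) for cytotoxicity, read by MTT assay, with a stated time of 24 h; on this read-out higher numbers stand for weaker inhibition and lower numbers for stronger inhibition:

- compound 1, `O=[N+]([O-])c1cc(Sc2nnnn2C2CCCCC2)cc([N+](=O)[O-])c1`: 153000 nM
- compound 2, `CCCCCCCCCCCCn1nnc(-c2cc([N+](=O)[O-])cc([N+](=O)[O-])c2)n1`: a limit, > 200000 nM
- compound 3, `Cc1ccc(Cn2nnc(-c3cc([N+](=O)[O-])cc([N+](=O)[O-])c3)n2)cc1`: 200000 nM

All three share a dinitrophenyl group attached to a small nitrogen-rich ring, and they differ in what hangs on that ring. Two of them give actual numbers in this assay. Compound 3 gives the higher of those two numbers, and compound 1 stands nearest to it with a slightly lower number; that gap lies within the usual scatter of such measurements, so the two cannot be told apart. Compound 2 gives only a limit in this assay, not a number (the limit of > 200000 nM in this assay, at which 1 of the 3 values shown sits).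

Compound 4, `COc1ccc(Cn2nnc(-c3cc([N+](=O)[O-])cc([N+](=O)[O-])c3)n2)cc1`, is compound 3 with one small change: methoxy in place of methyl on an aromatic carbon, in words, methoxy in place of methyl on an aromatic carbon. The rest of the molecule is untouched. Among the compounds with values here, no pair of measured compounds shows what such a swap does here, and the measured compounds all sit in the same high region of this assay, so no step beyond the scatter is expected from compound 3 to compound 4. Compound 4 is expected to give about 200000 nM in this assay, with a likely range from 100000 nM to 400000 nM, which corresponds to an estimated step of no change at the digits printed from compound 3 to compound 4 (within the scatter) from compound 3 to compound 4.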

Compound 4, half-maximal inhibitory concentration: 96000 nM
Compound 4: the middle estimate sits 2.1-fold (0.32 log units) above what was measured; the measured number lies below the stated range.
By their numbers in this assay, from the lowest: compounds 4, 1 and 3 (each within the scatter of the next, the first and the last beyond it).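

Within the data shown here, the methyl and methoxy compounds form the only pair here that differs in one place, so they give the first direct view of what a change on this aromatic ring, para to a large group, can do. In this assay, replacing methyl with methoxy gives a 2.1-fold lower number from compound 3 to compound 4 (0.32 log units; beyond the scatter), and since a lower number stands for stronger inhibition, this spot on the ring is not silent, though the step is modest and all the exact values remain in the same high region. Nothing in the data at hand explains why the swap has this effect.

From the compounds shown here alone, with a single pair, it remains open whether the step belongs to methoxy specifically or whether other groups at this place, such as an amine, a carboxylic acid, a chlorine atom or a longer chain like ethoxy, would move the number the same way, further or in the opposite direction. Going by these compounds, it also remains open whether the same swap would give a similar step on the ring of another core, or at another place on this ring.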